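This account rests on a few compounds, and the source may have more. Where it says the series, first, only, none or still open, it means among the compounds named here.

Measured so far in a functional assay on HL-60 cells (Homo sapiens) for antiproliferative activity; a higher number here means a weaker inhibitor, a lower number a stronger inhibitor:
Compound 1 `CCOC(=O)c1ccc(Oc2ccc(C#N)cc2)cc1`: > 20000 nM (a limit)
Compound 2 `CCOC(=O)c1ccc(Oc2ccc(OC)cc2)cc1`: > 20000 nM (a limit)

Neither entry is a true number. Compound 2 stands only at its limit of > 20000 nM, and all that can be said of the series is the limit of > 20000 nM in this assay, at which 2 of the 2 values shown sit. For the measured compounds named here, the one measured change, a step that the two limits leave unreadable from compound 1 to compound 2, therefore has no readable size and gives no direction.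

Compound 3 `CCOC(=O)c1ccc(Oc2ccc(Cl)cc2)cc1` keeps the shared core and changes one group, para to a large group: chloro in place of methoxy on an aromatic carbon. Going by the values given here, with compound 2 at > 20000 nM as the only guide, no real gain in this assay is expected, and a reported limit again seems the likeliest result. The expected change is a number no higher from compound 2 to compound 3 (the limit leaves the size open), an estimate that carries little certainty. For compound 3 the estimated value is 20000 nM, with an expected range from 10000 nM to 40000 nM.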

Compound 3, half-maximal inhibitory concentration: > 20000 nM
Compound 3 ended at the assay's limit; the forecaster's own chance of this, stated with the estimate: 80%; the middle value sits exactly at the limit.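

In this assay compound 3 gives > 20000 nM and this is a limit, not a number. The steps from compound 1 and from compound 2 to compound 3 therefore cannot be read. The compounds shown leave open which of the three groups, if any, gives the stronger inhibitor, since all the values sit at one limit: the limit of > 20000 nM in this assay, at which 3 of the 3 values shown sit.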